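A few compounds are considered here, and "the series" means these few. Any claim that something is new, unique, unknown or untested is made for them only; others in the source may bear on it.

Measured compounds:
Compound 1 `COc1cc2c(Oc3ccc(NC(=O)c4nn(-c5ccccc5)c(=O)c5ccccc45)cc3F)ccnc2cc1OCCCN1CCN(C)CC1`: in a functional assay on HT-29 cells (Homo sapiens) for cytotoxicity, read by MTT assay, with a stated time of 72 h (a lower number here means a stronger inhibitor, a higher number a weaker inhibitor), compound 1 gives 1140 nM.
Compound 2 `COc1cc2c(Oc3ccc(NC(=O)c4nn(-c5ccc(F)cc5)c(=O)c5ccccc45)cc3F)ccnc2cc1OCCCN1CCN(C)CC1`: in this assay compound 2 gives 320 nM.
Compound 3 `COc1cc2c(Oc3ccc(NC(=O)c4nn(-c5ccccc5)c(=O)c5ccccc45)cc3F)ccnc2cc1OCCCN1CCC(C)CC1`: in this assay compound 3 gives 1040 nM.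

Among these three numbers, compound 3 stands second highest. Its value and that of compound 1 differ by less than the usual scatter of the measurement, so the two cannot be told apart, whereas compound 2 sits below both by a gap beyond the scatter.

Compound 4 `COc1cc2c(Oc3ccc(NC(=O)c4nn(-c5ccc(F)cc5)c(=O)c5ccccc45)cc3F)ccnc2cc1OCCCN1CCC(C)CC1` has not yet been measured in this assay. It differs from compound 3 in one place: fluoro in place of hydrogen on an aromatic carbon. The same change has been seen once already, on the pair that shares the other side chain: a 3.6-fold lower number from compound 1 to compound 2 (0.55 log units; beyond the scatter). That step lies beyond the scatter, and the change from compound 1 to compound 3 itself was within the scatter, so the two side chains appear to behave alike here. A step of similar size, towards a lower number, is therefore expected from compound 3 to compound 4, namely a 3.5-fold lower number from compound 3 to compound 4 (0.54 log units; beyond the scatter). On that basis compound 4 is estimated at 300 nM in this assay, with a likely range from 150 nM to 700 nM.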

Compound 4, half-maximal inhibitory concentration: 330 nM
Compound 4: middle estimate off by 1.1-fold (0.04 log units), on the low side, and the stated range covers the measured number.
By their numbers in this assay, from the lowest: compounds 2 and 4 (each within the scatter of the next); then compounds 3 and 1 (each within the scatter of the next).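

In this assay, the change from phenyl to 4-fluorophenyl gives a 3.2-fold lower number from compound 3 to compound 4 (0.50 log units; beyond the scatter), so the step first seen with the 4-methylpiperazin-1-yl side chain also appears with the 4-methylpiperidin-1-yl side chain, and the two steps agree: the same change on two cores in this assay, a 3.6-fold lower number (0.55 log units; beyond the scatter) from compound 1 to compound 2 and a 3.2-fold lower number (0.50 log units; beyond the scatter) from compound 3 to compound 4, 1.1-fold (0.05 log units) apart, within the scatter of two such steps. The swap between these two side chains can now be read on the 4-fluorophenyl pair as well, as a 1.0-fold higher number from compound 2 to compound 4 (0.01 log units; within the scatter), and it agrees with the reading on the phenyl pair: the same change on two cores in this assay, a 1.1-fold lower number (0.04 log units; within the scatter) from compound 1 to compound 3 and a 1.0-fold higher number (0.01 log units; within the scatter) from compound 2 to compound 4, 1.1-fold (0.05 log units) apart, within the scatter of two such steps. Across these four compounds, the two changes therefore appear to act independently, with no compound going against this.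

On these data alone, whether chloro, methoxy or a nitrile in place of the fluoro would give a similar step remains open. So does whether the independence would hold with a morpholin-4-yl group or a longer chain on the other side of the molecule.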